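Adding a methoxy group to the phenyl ring of compound 1

This account rests on a few compounds, and the source may have more. Where it says the series, first, only, none or still open, it means among the compounds named here.

Compound 1 `c1ccc(-c2nnc(-c3c[nH]c4ccccc34)o2)cc1` is the starting point. In a functional assay on MIA PaCa-2 cells (Homo sapiens) for cytotoxicity, read by MTT assay (on this read-out lower numbers stand for stronger inhibition and higher numbers for weaker inhibition), compound 1 gives only a limit of the assay, > 1000000 nM. Compound 2 `c1cncc(-c2nnc(-c3c[nH]c4ccccc34)o2)c1` gives 900 nM in this assay. Going by the values given here, the single measured step, an at least 1100-fold lower number from compound 1 to compound 2 (3.04 log units; beyond the scatter), changes the same ring but in another way, so it bears only loosely on compound 3 `COc1ccc(-c2nnc(-c3c[nH]c4ccccc34)o2)cc1`, which carries methoxy in place of hydrogen on an aromatic carbon. With compound 1 sitting at the limit (the limit of > 1000000 nM in this assay, at which 1 of the 2 values shown sits), a number for compound 3 would itself mean a drop, yet its size cannot be read from the data. Compound 3 is expected at 200000 nM, between 5000 nM and 1000000 nM. The step this estimate means is expected to be an at least 5.0-fold lower number from compound 1 to compound 3 (0.69 log units; beyond the scatter).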

Compound 3, half-maximal inhibitory concentration: > 1000000 nM
Compound 3: no number, only a limit; the forecaster's own chance of this, stated with the estimate: 50%; middle value at least 5.0-fold (0.69 log units) away from the limit.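

In this assay, going by these compounds alone, compound 3 gives > 1000000 nM, which is a limit and not a number, and compound 1 also sits at a limit, so no step between compound 1 and compound 3 can be read. Going by these compounds, whether methoxy in place of hydrogen changes the read-out at all stays open.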